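The source may hold more compounds than are shown below. What is called first, only, known or untested is meant among the compounds shown, and "the series" means these compounds.

Compound 1, `Cc1cc(C)cc(NC(=O)CN2CCC(c3cccc[n+]3[O-])CC2)c1`, was tested in a functional assay on HEK293 cells for agonist activity at D(4) dopamine receptor (Homo sapiens), read by FLIPR (a lower number here means that less compound is needed, a higher number that more compound is needed for the effect), and gave 52 nM. Compound 2, `O=C(NCN1CCC(c2cccc[n+]2[O-])CC1)c1ccc(F)c(Cl)c1`, has the same core joined to a different amide partner; in this assay compound 2 gives 63 nM. Of the two measured numbers compound 1 stands at the low end, though compound 2 sits so close that the two cannot be told apart within the scatter of this kind of measurement.

Compound 3, `O=C(CN1CCC(c2cccc[n+]2[O-])CC1)Nc1cccc(Cl)c1`, has not yet been measured. It differs from compound 1 in one place: 3-chlorophenyl in place of 3,5-dimethylphenyl on an amide-type nitrogen. The amide, the piperidine and the pyridine N-oxide are kept unchanged.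

Within the data shown here, no pair of measured compounds shows this kind of change, so there is no measured step to lean on. Both measured compounds lie close together despite quite different amide partners, which suggests the assay tolerates variation here. Compound 3 is therefore expected to stay near compound 1, with a step of a 1.6-fold higher number from compound 1 to compound 3 (0.21 log units; within the scatter) that may well lie within the scatter, leaning slightly toward a higher number. The estimate for compound 3 is 85 nM, with a range from 30 nM to 250 nM.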

Compound 3, half-maximal effective concentration: 62 nM
Estimate against measurement, compound 3: 1.4-fold (0.14 log units) above; the measured number falls inside the stated range.
By their numbers in this assay, from the lowest: compounds 1, 3 and 2 (each within the scatter of the next).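

In this assay, among these compounds, the exchange of 3,5-dimethylphenyl for 3-chlorophenyl on an amide-type nitrogen gives the first step in this account between compounds that differ in one place: a 1.2-fold higher number from compound 1 to compound 3 (0.08 log units; within the scatter), which lies within the scatter. At this place, therefore, the two groups cannot be told apart in this read-out, although one carries two methyl groups and the other a single chlorine, and the amide-type nitrogen, its carbonyl carbon and the rest of the core of compound 1 stay as they were. No measurement shown here offers any explanation for this result.

Among the compounds shown here, this single pair shows only that one substituted phenyl group can stand in for another at this place without a step beyond the scatter, and it cannot separate the loss of the methyl groups from the arrival of the chlorine. Going by these compounds, whether the number would stay as close with a carboxylic acid or an amine on the phenyl ring, or with a longer chain in place of the phenyl ring, remains open.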